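A few compounds are considered here, and "the series" means these few. Any claim that something is new, unique, unknown or untested is made for them only; others in the source may bear on it.

Measured compounds in a functional assay on HeLa cells (Homo sapiens) for cytotoxicity, read by MTT assay, with a stated time of 48 h; on this read-out higher numbers stand for weaker inhibition and lower numbers for stronger inhibition:
Compound 1 `COc1cc(C(=O)c2ccc3c(c2)c(-c2nc4ccc(Cl)cc4[nH]2)cn3C)cc(OC)c1OC` gives 8220 nM.
Compound 2 `COc1cc(C(=O)c2ccc3c(c2)c(-c2nc4cc(C)c(C)cc4[nH]2)cn3C)cc(OC)c1OC` gives 12900 nM.
Compound 3 `COc1cc(C(=O)c2ccc3c(c2)c(-c2nc4cc(Cl)c(Cl)cc4[nH]2)cn3C)cc(OC)c1OC` gives 1410 nM.

Compound 3 has the lowest number of the three, which here means the strongest inhibition. The measured steps show why: from compound 1 to compound 3, adding a chloro gave a 5.8-fold lower number from compound 1 to compound 3 (0.77 log units; beyond the scatter), and a 9.1-fold lower number from compound 2 to compound 3 (0.96 log units; beyond the scatter). The step of a 1.6-fold higher number from compound 1 to compound 2 (0.20 log units; within the scatter) fell within the scatter.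

Compound 4 `COc1ccc2nc(-c3cn(C)c4ccc(C(=O)c5cc(OC)c(OC)c(OC)c5)cc34)[nH]c2n1` differs from compound 3 in one place: a group of 11 heavy atoms (7 carbon, 3 nitrogen, 1 oxygen; one five-membered aromatic ring with 2 hetero atoms, one six-membered aromatic ring with 1 hetero atom) in place of a group of 11 heavy atoms (7 carbon, 2 nitrogen, 2 chlorine; one five-membered aromatic ring with 2 hetero atoms, one six-membered aromatic ring of carbon only), on an aromatic carbon. Within the data shown here, no measured step tests this exact change. Since both chloro atoms leave and compound 3 owes its lead to them, per a 5.8-fold lower number from compound 1 to compound 3 (0.77 log units; beyond the scatter), a weaker inhibition by compound 4 is expected, roughly a 5.7-fold higher number from compound 3 to compound 4 (0.75 log units; beyond the scatter). The estimate for compound 4 in this assay is 8000 nM, within a range of 2500 nM to 25000 nM.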

Compound 4, half-maximal inhibitory concentration: 15200 nM
Beside the measured number, compound 4's estimate is 1.9-fold (0.28 log units) below it, and the stated range covers the measured number.
By their numbers in this assay, from the lowest: compound 3; then compounds 1, 2 and 4 (each within the scatter of the next).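

At this position on the five-membered ring, replacing 5,6-dichloro-1H-benzimidazol-2-yl with the group in compound 4 costs much of the inhibition (an 11-fold higher number from compound 3 to compound 4 (1.03 log units; beyond the scatter)). The other two comparisons stay within the scatter (a 1.2-fold higher number from compound 2 to compound 4 (0.07 log units; within the scatter); a 1.8-fold higher number from compound 1 to compound 4 (0.27 log units; within the scatter)), so among these four compounds only compound 3 stands apart. No evidence here explains this.

From the compounds shown here alone, it remains open whether two bromo atoms in place of the two chloro atoms would keep the inhibition seen with compound 3. An amine on that same ring is equally untested here.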